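Aryl variation on the oxadiazole of a shared core

The source may hold more compounds than are shown below. What is called first, only, known or untested is meant among the compounds shown, and "the series" means these compounds.

Measured compounds:
- compound 1, `N#Cc1ccc(-c2cnc3[nH]cc(-c4nnc(-c5ccc(Cl)cc5)o4)c(=O)c3c2)cc1`: 11.5%
- compound 2, `CS(=O)(=O)c1ccc(-c2cnc3[nH]cc(-c4nnc(-c5ccc(F)cc5)o4)c(=O)c3c2)cc1`: 9.45%
- compound 3, `CS(=O)(=O)c1ccc(-c2cnc3[nH]cc(-c4nnc(-c5ccncc5)o4)c(=O)c3c2)cc1`: 3.49%

In a functional assay on HepG2 cells (Homo sapiens) for inhibition, read by MTT assay, with a stated time of 24 h, tested at 5 uM (on this read-out higher numbers stand for more inhibition of growth at the one concentration tested and lower numbers for less inhibition of growth), compound 2 gives 9.45% and stands second highest of the three numbers; compound 1 gives 11.5% and compound 3 gives 3.49%, both within the scatter of compound 2, so no order among the three can be read from these values.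

Compound 4, `Cc1cccc(-c2nnc(-c3c[nH]c4ncc(-c5ccc(S(C)(=O)=O)cc5)cc4c3=O)o2)c1`, differs from compound 2 in one place: 3-methylphenyl in place of 4-fluorophenyl on an aromatic carbon.

Within the data shown here, the only measured step at this position is a number 6 percentage points lower from compound 2 to compound 3 (within the scatter), and it stays within the scatter. Among the measured compounds shown here, no step exchanges one carbon-only six-membered aromatic ring for another, so there is nothing that points to a change beyond the scatter for compound 4 in this assay either.

Compound 4 is therefore expected to give about 9% in this assay, with a range from 0% to 20%. The estimated step of a number 0.5 percentage points lower from compound 2 to compound 4 (within the scatter) is expected to lie within the scatter.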

Compound 4, percent growth inhibition at one concentration: 13.2%
Compound 4: middle estimate off by 4.2 percentage points, on the low side; low and high end bracket the measured number.
By their numbers in this assay, from the lowest: compounds 3, 2, 1 and 4 (each within the scatter of the next).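

In this assay, among these compounds, 3-methylphenyl in place of 4-fluorophenyl gives a number 3.8 percentage points higher from compound 2 to compound 4 (within the scatter), the first exchange at this position between two carbon-only six-membered aromatic rings. 3-Methylphenyl in place of pyridin-4-yl gives a number 9.7 percentage points higher from compound 3 to compound 4 (within the scatter), so 4-fluorophenyl, pyridin-4-yl and 3-methylphenyl all lie within the scatter of one another at this position on the shared core. No measured property of these groups bears on this result, and no reason for it can be stated.

Open, as far as these compounds go, is whether an aryl group carrying an amine or a carboxylic acid, or a longer chain in place of the aryl ring, would move the number beyond the scatter. Also open, from the compounds shown here alone, is whether the place of a substituent on the phenyl ring matters on its own, as 4-fluorophenyl and 3-methylphenyl differ in both the substituent and its place.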